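Amide-side variation on the shared core

The source may hold more compounds than are shown below. What is called first, only, known or untested is meant among the compounds shown, and "the series" means these compounds.

Compound 1 `CCCSc1nc(Cl)c2c(n1)N(CCNC(=O)OC(C)(C)C)C(C(=O)N1CCN(C)CC1)N2` and compound 2 `CCCSc1nc(Cl)c2c(n1)N(Cc1cccs1)C(C(=O)N1CCN(C)CC1)N2` keep the same amide on the shared core; in a functional assay on TE-1 cells (Homo sapiens) for antiproliferative activity, read by MTT assay, with a stated time of 72 h (a higher number here means a weaker inhibitor, a lower number a stronger inhibitor), compound 1 gives 51800 nM and compound 2 gives 39400 nM. Within the data shown here, the step of a 1.3-fold lower number from compound 1 to compound 2 (0.12 log units; within the scatter) is the only measured step, and it sits on a saturated chain carbon bound to a nitrogen on an aromatic ring, not on the amide side. Compound 3 `CCCSc1nc(Cl)c2c(n1)N(Cc1ccccc1)C(C(=O)NCCNC(=O)OC(C)(C)C)N2` carries an open-chain amide instead. In this assay compound 3 reports only a limit, > 64000 nM, so no number places it against compounds 1 and 2. The series as a whole sits at high concentrations, with one compound at the limit of > 64000 nM in this assay, at which 1 of the 3 values shown sits.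

Compound 4 `CCCSc1nc(Cl)c2c(n1)N(Cc1ccccc1)C(C(=O)NCC(C)C)N2` differs from compound 3 by isopropyl in place of ((tert-butoxycarbonyl)amino)methyl on a saturated chain carbon bound to an amide-type nitrogen. Among the measured compounds shown here, no measured step touches this place, and the one step available, lying within the scatter, gives no direction for the amide side. With compound 3 known only as a limit, the expectation for compound 4 is a number near that limit, and a limit is again a real possibility. Compound 4 is estimated at 70000 nM, within 30000 nM to 160000 nM in this assay. The expected step is a step that the limit leaves unreadable from compound 3 to compound 4.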

Compound 4, half-maximal inhibitory concentration: 46600 nM
The estimate for compound 4 lay 1.5-fold (0.18 log units) above the measured number; the measured number falls inside the stated range.
By their numbers in this assay, from the lowest: compounds 2, 4 and 1 (each within the scatter of the next). At a limit, above all of these: compound 3.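

The change from ((tert-butoxycarbonyl)amino)methyl to isopropyl, on a saturated chain carbon bound to an amide-type nitrogen, gives an at least 1.3-fold lower number from compound 3 to compound 4 (0.13 log units; that floor lies within the scatter) in this assay. Compound 4 gives 46600 nM, so an open-chain amide carrying isobutyl in place of 2-((tert-butoxycarbonyl)amino)ethyl returns a readable number on the shared core. Compound 3 is known only as a limit, and the step is a floor with no upper bound: the limit of > 64000 nM in this assay, at which 1 of the 4 values shown sits.

On these data alone, whether a primary amine or a carboxylic acid at the end of this chain, or a longer alkyl chain in place of isobutyl, would move the number beyond the scatter remains open. Also open, as far as these compounds go, is whether thiophen-2-yl in place of phenyl, on the saturated chain carbon bound to a nitrogen on an aromatic ring, would shift the number for the isobutyl amide of compound 4.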